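The source may hold more compounds than are shown below. What is called first, only, known or untested is meant among the compounds shown, and "the series" means these compounds.

In a functional assay on PC-3 cells (Homo sapiens) for antiproliferative activity, read by sulforhodamine B assay (on this read-out lower numbers stand for stronger inhibition of growth and higher numbers for weaker inhibition of growth), compound 1 `CC(C)CCCOc1cccc(O)c1C(=O)/C=C/c1ccc(O)cc1` gives 3600 nM. Compound 3 `CCCCCCOc1cccc(O)c1C(=O)/C=C/c1ccc(O)cc1`, which carries a hexyl chain, gives > 30000 nM, and this is a limit of the assay, not a number. Compound 3 therefore sits at the limit of > 30000 nM in this assay, at which 2 of the 3 values shown sit. Compound 2 `COc1cccc(OCCC(C)(C)C)c1C(=O)/C=C/c1ccc(O)cc1` gives > 30000 nM, which is also a limit.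

Compound 4 `CC(C)(C)CCOc1cccc(O)c1C(=O)/C=C/c1ccc(O)cc1` has the same atoms as compound 3, joined differently: tert-butyl in place of butyl on a saturated chain carbon, two bonds along the chain from an oxygen on an aromatic ring. In words, tert-butyl stands in place of butyl on a saturated chain carbon, two bonds along the chain from an oxygen on an aromatic ring. The hexyl chain thus becomes 3,3-dimethylbutyl.

Within the data shown here, one measured step bears on this change: an at least 8.3-fold higher number from compound 1 to compound 3 (0.92 log units; beyond the scatter). It shows the branched chain of compound 1 giving the lower number, and compound 4 also has a branched chain end. This points to a lower number for compound 4 in this assay, though the evidence is thin. It is a single step, and isopropyl is not tert-butyl. Compound 2 goes against the pattern, since it also ends its chain in tert-butyl and yet stays at its limit.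

The expected change is an at least 3.3-fold lower number from compound 3 to compound 4 (0.52 log units; beyond the scatter). Compound 4 is estimated at 9000 nM, with an expected range of 2500 nM to 30000 nM.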

Compound 4, concentration for 50% growth inhibition: 3220 nM
Compound 4: the middle estimate sits 2.8-fold (0.45 log units) above what was measured; measured number inside the range.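

In this assay, tert-butyl in place of butyl on a saturated chain carbon, two bonds along the chain from an oxygen on an aromatic ring, gives an at least 9.3-fold lower number from compound 3 to compound 4 (0.96 log units; beyond the scatter), so a second branched chain end now stands against the unbranched hexyl chain, where before there was only compound 1. The two branched chains cannot be told apart in this assay, as tert-butyl in place of isobutyl gives a 1.1-fold lower number from compound 1 to compound 4 (0.05 log units; within the scatter). The tert-butyl end is still not enough on its own: compound 2 carries it too, and hydrogen in place of methyl on the oxygen on the aromatic ring gives an at least 9.3-fold lower number from compound 2 to compound 4 (0.96 log units; beyond the scatter), so with this chain the free hydroxyl group goes with the lower number and compound 2 is the exception to the branching pattern.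

From the compounds shown here alone, how large the steps from compound 2 and compound 3 truly are stays open, because each of them starts from a limit of the assay and not from a number: the limit of > 30000 nM in this assay, at which 2 of the 4 values shown sit. Whether a longer branched chain, or an amine or a carboxylic acid at the end of the chain, would keep this level of growth inhibition also stays open.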